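Trimming compound 2 to the methylamino analogue, compound 4

This account rests on a few compounds, and the source may have more. Where it says the series, first, only, none or still open, it means among the compounds named here.

Three measured compounds share one core and differ only in the halogen on the benzyl group: compound 1 `CCCCC#Cc1nc(NCc2cccc(Br)c2)c2ncn([C@H]3[C@H](O)[C@H](O)[C@@H]4C[C@@H]43)c2n1`, compound 2 `CCCCC#Cc1nc(NCc2cccc(Cl)c2)c2ncn([C@H]3[C@H](O)[C@H](O)[C@@H]4C[C@@H]43)c2n1` and compound 3 `CCCCC#Cc1nc(NCc2cccc(I)c2)c2ncn([C@H]3[C@H](O)[C@H](O)[C@@H]4C[C@@H]43)c2n1`. In an assay on CHO cells for displacement of a labelled ligand from adenosine receptor A1 (Homo sapiens), read by scintillation counting, with a stated time of 60 min, tested at 10 uM (on this read-out higher numbers stand for more inhibition at the one concentration tested (going by the name of the read-out) and lower numbers for less inhibition), compound 1 gives 38%, compound 2 gives 19% and compound 3 gives 48%. Compound 2 stands lowest of the three numbers: the step of a number 19 percentage points lower from compound 1 to compound 2 (beyond the scatter) lies beyond the scatter, as does a number 29 percentage points higher from compound 2 to compound 3 (beyond the scatter), while a number 10 percentage points higher from compound 1 to compound 3 (within the scatter) stays within it.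

Compound 4 `CCCCC#Cc1nc(NC)c2ncn([C@H]3[C@H](O)[C@H](O)[C@@H]4C[C@@H]43)c2n1` differs from compound 2 as follows: hydrogen in place of 3-chlorophenyl on a saturated chain carbon bound to a nitrogen on an aromatic ring. Going by the values given here, no measured step removes the aryl group; all three only exchange one halogen for another, so they bear on this change only indirectly. Among compounds 1 to 3 the chloro compound sits lowest and the iodo compound highest, so taking the whole 3-chlorophenyl away is expected to move the number further down rather than up, though by an uncertain amount. The expected step is a number 11 percentage points lower from compound 2 to compound 4 (beyond the scatter), below the scatter boundary. For compound 4 an inhibition of 8% is estimated, with a range from -8% to 28%.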

Compound 4, a percentage reported as inhibition, at one concentration (the size of the read-out at that concentration, not a potency): 14%
Compound 4: the middle estimate sits 6 percentage points below what was measured; the range from low to high includes it.
By their numbers in this assay, from the lowest: compounds 4 and 2 (each within the scatter of the next); then compounds 1 and 3 (each within the scatter of the next).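

In this assay hydrogen in place of 3-chlorophenyl gives a number 5 percentage points lower from compound 2 to compound 4 (within the scatter) and so compound 2 and compound 4 cannot be told apart here: on the shared core the 3-chlorobenzyl group adds nothing readable over methyl. The bromo and iodo analogues do separate from the methylamino compound, with a number 24 percentage points lower from compound 1 to compound 4 (beyond the scatter) and a number 34 percentage points lower from compound 3 to compound 4 (beyond the scatter) as their steps, so among these four compounds the aryl group registers on this read-out only when it carries one of those two halogens. Nothing available on these compounds gives a reason for this dependence on the halogen.

Open, as far as these compounds go, is where a plain benzyl group without any halogen, or a 3-methylbenzyl group, would fall, which would show whether the bromo and iodo substituents or the ring itself account for the separation from compound 4. Also open, from the compounds shown here alone, is whether a longer chain such as butylamino, or a free amino group, in place of methylamino would stay at this level, and how these single-concentration readings relate to potency.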